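The source may report more compounds than this note shows. Statements on the series, on what has been measured and on what is new or still open speak of the compounds shown alone.

Measured so far:
compound 1, `COc1cc(C)cc(-c2c(-c3ccnc(-c4ccc(C(C)=O)cc4)c3)cnn2CC#N)c1` — 99%
compound 2, `Cc1cc(O)cc(-c2nn(CC#N)cc2-c2ccnc(-c3ccc(Oc4ccccc4)cc3)c2)c1` — 94%
compound 3, `Cc1cc(O)cc(-c2nn(CC#N)cc2-c2ccnc(-c3ccc(N(C)C)cc3)c2)c1` — 93%

The three measured compounds were all tested in a functional assay on SNB-19 cells (Homo sapiens) for cytotoxicity, read by sulforhodamine B assay, with a stated time of 48 h, tested at 100 nM; a higher number here means a weaker effect of the compound at the concentration tested, a lower number a stronger effect. In this assay compound 1 gives 99%, the highest of the three numbers, though the gaps to compound 2 and compound 3 are both within the scatter, so no order among them can be claimed. Compound 2 and compound 3 share a core that carries a hydroxyl in place of the methoxy found in compound 1, and differ from each other only in one group: a number 1 percentage points lower from compound 2 to compound 3 (within the scatter).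

Compound 4, `COc1cc(C)cc(-c2c(-c3ccnc(-c4ccc(N(C)C)cc4)c3)cnn2CC#N)c1`, has not been measured. It differs from compound 1 in one place: dimethylamino in place of acetyl on an aromatic carbon. For the measured compounds named here, the only measured step that bears on this change is the one from compound 2 to compound 3, where a dimethylamino group likewise entered the same position of the same phenyl ring; that step was within the scatter. Going by the values given here, no step with acetyl leaving is available. He therefore expects no change beyond the scatter in this assay, so that a number 3 percentage points lower from compound 1 to compound 4 (within the scatter) would be a small step.

Compound 4 is estimated at 96%, in the range 86% to 105%.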

Compound 4, a percentage reported as activity, at one concentration (the size of the read-out at that concentration, not a potency): 27%
For compound 4 the middle estimate is 69 percentage points above the measured one; the measured number lies below the stated range.
By their numbers in this assay, from the lowest: compound 4; then compounds 3, 2 and 1 (each within the scatter of the next).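

In this assay the change from 4-acetylphenyl to 4-(dimethylamino)phenyl is not silent on the methoxy-bearing core: it gives a number 72 percentage points lower from compound 1 to compound 4 (beyond the scatter) and so shows that this position can carry a large step, of which the earlier step of a number 1 percentage points lower from compound 2 to compound 3 (within the scatter) gave no sign. Compound 3 carries the same dimethylamino group and differs from compound 4 only in having hydroxyl in place of methoxy, yet compound 3 gives 93% while compound 4 gives 27% in this assay, so among the compounds shown the dimethylamino group goes with a low number only when the methoxy is present. No measurement at hand gives a cause for this drop.

As far as these compounds go, whether a plain amino group or a ring amine such as morpholine would give a similarly low number at this place on the core of compound 4 stays open. From the compounds shown here alone, it also stays open what the acetyl group would give on the hydroxyl-bearing core, and so whether the two places act together or apart.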